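This account rests on a few compounds, and the source may have more. Where it says the series, first, only, none or still open, it means among the compounds named here.

Among the compounds with values here, in a functional assay on MDA-MB-231 cells (Homo sapiens) for antiproliferative activity, read by MTT assay, with a stated time of 72 h (on this read-out lower numbers stand for stronger inhibition and higher numbers for weaker inhibition), compound 1 `NC1=NC2(CCSCC2)N(OCCCOc2ccc(Cl)c(Cl)c2)C(N)=N1` gives 10 nM and holds the lower of the two numbers so far, while compound 2 `NC1=NC2(CCOCC2)N(OCCCOc2cccc(Cl)c2)C(N)=N1` gives 1020 nM with a gap beyond the scatter. Within the data shown here, these two differ in more than one place, so they offer no single-change step. Compound 3 `NC1=NC2(CCSCC2)N(OCCCOc2cccc(Br)c2)C(N)=N1` carries 3-bromophenyl in place of 3,4-dichlorophenyl on an oxygen on a saturated carbon, with 3-bromophenyl in place of 3,4-dichlorophenyl on an oxygen on a saturated carbon as the counted difference. A moderate loss is expected in this assay with a 4.0-fold higher number from compound 1 to compound 3 (0.60 log units; beyond the scatter) as the estimated step toward a higher number. For compound 3 the expected value is 40 nM within an estimated range from 10 nM to 200 nM for this measurement.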

Compound 3, half-maximal inhibitory concentration: 60 nM
For compound 3 the middle estimate is 1.5-fold (0.18 log units) below the measured one; measured number inside the range.
By their numbers in this assay, from the lowest: compound 1; then compound 3; then compound 2.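

Within the data shown here, this is the first single-change step: in this assay, 3-bromophenyl in place of 3,4-dichlorophenyl on an oxygen on a saturated carbon gives a 6.0-fold higher number from compound 1 to compound 3 (0.78 log units; beyond the scatter) and so shows that this position responds to the change, though only modestly. No measurement on hand accounts for the step.

Going by these compounds, the step swaps two chlorine atoms for one bromine, so the contribution of each part stays open; a 3-chlorophenyl group at this position would help separate them. Also open, on these data alone, is how an aminophenyl group or a longer chain would read here.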